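A few compounds are considered here, and "the series" means these few. Any claim that something is new, unique, unknown or untested is made for them only; others in the source may bear on it.

Compound 1 `ClCc1ccc(Cn2cnc3c(Cl)ncnc32)cc1` and compound 3 `ClCc1ccccc1Cn1cnc2c(Cl)ncnc21` are built from the same atoms joined differently; the difference between the two cores is not broken down here. In a functional assay on UO-31 cells (Homo sapiens) for cytotoxicity, read by sulforhodamine B assay, with a stated time of 48 h (a lower number here means that less compound is tolerated, a higher number that more compound is tolerated), compound 1 gives only a limit of the assay, > 100000 nM. Compound 2 `Nc1nc(Cl)c2ncn(Cc3ccc(CCl)cc3)c2n1` differs from compound 1 by amino in place of hydrogen on an aromatic carbon, and in this assay compound 2 gives 55000 nM, a step of an at least 1.8-fold lower number from compound 1 to compound 2 (0.25 log units; that floor lies within the scatter); its size is uncertain since the start of that step sits at the limit of > 100000 nM in this assay, at which 1 of the 3 values shown sits. In this assay compound 3 gives 61700 nM, close to compound 2.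

Compound 4 `Nc1nc(Cl)c2ncn(Cc3ccccc3CCl)c2n1` has not yet been measured in this assay. It differs from compound 3 by amino in place of hydrogen on an aromatic carbon, the same change that leads from compound 1 to compound 2, made at a place described in the same words. Since that earlier step an at least 1.8-fold lower number from compound 1 to compound 2 (0.25 log units; that floor lies within the scatter) is known only as a floor within the scatter, the expected step is modest: a 1.4-fold lower number from compound 3 to compound 4 (0.14 log units; within the scatter) is anticipated. Compound 4 is therefore estimated at 45000 nM, with a likely range from 20000 nM to 100000 nM, and the measurement will show how it falls.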

Compound 4, concentration lethal to 50% of the cells: > 100000 nM
Compound 4: only a limit was reported (the forecaster's own chance of this, stated with the estimate: 15%); middle value at least 2.2-fold (0.34 log units) away from the limit.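

In this assay, amino in place of hydrogen on an aromatic carbon gives an at least 1.6-fold higher number from compound 3 to compound 4 (0.20 log units; that floor lies within the scatter), and the change therefore does not carry over unchanged from one core to the other: the same change on two cores in this assay, an at least 1.8-fold lower number (0.25 log units; that floor lies within the scatter) from compound 1 to compound 2 and an at least 1.6-fold higher number (0.20 log units; that floor lies within the scatter) from compound 3 to compound 4, at least 2.9-fold (0.46 log units) apart, beyond the scatter of two such steps. The two steps point in opposite directions, a finding that holds for these two pairs only and does not establish a rule for the series. The pairs do not show how large either step is, or what in the two cores sets them apart, since each step has one end at a limit of the assay: the limit of > 100000 nM in this assay, at which 2 of the 4 values shown sit.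

The compounds shown leave open whether the same split between the cores would appear with a methylamino or a hydroxyl group on that aromatic carbon in place of amino. They also leave open how either core would respond if the chloromethyl group gave way to a longer chain such as chloroethyl.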